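Cytotoxicity at the Assay Limit Across a Shared Core

A few compounds are considered here, and "the series" means these few. Any claim that something is new, unique, unknown or untested is made for them only; others in the source may bear on it.

Three compounds built on one shared core have been examined in a functional assay on HepG2 cells (Homo sapiens) for cytotoxicity, with a stated time of 72 h; on this read-out higher numbers stand for an effect only at larger amounts of compound and lower numbers for an effect already at smaller amounts. Compound 1 `C=C[C@@](C)(/C=C/c1ccc(O)c(/C=C/C(=O)NCc2ccc(C(F)(F)F)cc2)c1)CCC=C(C)C` gives in this assay only a limit, > 52000 nM. Compound 2 `C=C[C@@](C)(/C=C/c1ccc(Nc2ccc(OC)c(OC)c2)cc1)CCC=C(C)C` likewise gives only a limit, > 52000 nM. Compound 3 `C=C[C@@](C)(/C=C/c1ccc(Nc2ccc(OC)c(F)c2)cc1)CCC=C(C)C` stands at the same limit, > 52000 nM. The step that the two limits leave unreadable from compound 2 to compound 3 cannot be read, as the limit of > 52000 nM in this assay, at which 3 of the 3 values shown sit, shows. Compound 4 `C=C[C@@](C)(/C=C/c1ccc(Nc2ccc(Cl)cc2)cc1)CCC=C(C)C` is the untested member, differing from compound 3 by 4-chlorophenyl in place of 3-fluoro-4-methoxyphenyl on a nitrogen on an aromatic ring. Going by the values given here, no measured step bears directly on this change; the only comparison altering the same group, a step that the two limits leave unreadable from compound 2 to compound 3, is unreadable. Among the compounds with values here, with every value so far resting at the limit, compound 4 is expected to show no departure beyond the scatter in this assay, and the step that the limit leaves unreadable from compound 3 to compound 4 is expected to be essentially nil. Compound 4 is estimated at 60000 nM, within a range of 30000 nM to 150000 nM, and it is expected most likely to be reported once more only as a limit.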

Compound 4, half-maximal effective concentration: > 52000 nM
Compound 4: only a limit was reported; the forecaster's own chance of this, stated with the estimate: 85%; the middle value lies beyond the limit too.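

Going by these compounds alone, compound 3 and compound 4 each give only a limit in this assay, so no step between them can be read: the limit of > 52000 nM in this assay, at which 4 of the 4 values shown sit. The compounds shown leave open how compound 1 through compound 4 would rank, and whether any of these groups changes the cytotoxicity at all.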